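Swapping a Five-Atom Group for an Amino Group

This account rests on a few compounds, and the source may have more. Where it says the series, first, only, none or still open, it means among the compounds named here.

Compound 1 `Nc1cc(-c2ccc(Cl)cc2)nn1-c1ccc(Br)cc1` and compound 3 `CN(C)/C=N/c1cc(-c2ccc(Cl)cc2)nn1-c1ccc(Br)cc1` share one core, while compound 2 `CN(C)/C=N/c1c(C=O)c(-c2ccccc2)nn1-c1ccccc1` has another; the difference between the two cores is not broken down here. In a functional assay on NCI-H226 cells (Homo sapiens) for inhibition, read by MTT assay, with a stated time of 72 h (on this read-out lower numbers stand for stronger inhibition of growth and higher numbers for weaker inhibition of growth), compound 1 gives 58700 nM, compound 3 gives 59800 nM, and compound 2 gives 31400 nM. The change from compound 3 to compound 1 is one nitrogen atom in place of a group of 5 heavy atoms (3 carbon, 2 nitrogen; no ring), on an aromatic carbon, and it made a step of a 1.0-fold lower number from compound 3 to compound 1 (0.01 log units; within the scatter). Compound 4 `Nc1c(C=O)c(-c2ccccc2)nn1-c1ccccc1` is not yet measured; it arises from compound 2 through (one nitrogen atom in place of a group of 5 heavy atoms (3 carbon, 2 nitrogen; no ring), on an aromatic carbon), the same kind of change, though the surroundings differ: here the place is next to the ring atom that bears a formyl group and next to the ring atom that bears a phenyl group, not next to the ring atom that bears a 4-bromophenyl group. That earlier step lay within the scatter, so a similar outcome is expected. The expected step in this assay is a 1.0-fold lower number from compound 2 to compound 4 (0.01 log units; within the scatter). Compound 4 is therefore estimated at 31000 nM, between 15000 nM and 65000 nM.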

Compound 4, concentration for 50% growth inhibition: > 100000 nM
Compound 4 ended at the assay's limit; the forecaster's own chance of this, stated with the estimate: 10%; middle value at least 3.2-fold (0.50 log units) away from the limit.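

In this assay, putting an amino group in place of the five-atom group on the core of compound 2 made an at least 3.1-fold higher number from compound 2 to compound 4 (0.50 log units; beyond the scatter). Compound 4 stands at a limit of the assay, not at a number: the limit of > 100000 nM in this assay, at which 1 of the 4 values shown sits. The change therefore does not carry over equally between these two cores, though two pairs cannot show which feature of the cores is responsible, nor how large the gap truly is: the same change on two cores in this assay, a 1.0-fold lower number (0.01 log units; within the scatter) from compound 3 to compound 1 and an at least 3.1-fold higher number (0.50 log units; beyond the scatter) from compound 2 to compound 4, at least 3.2-fold (0.51 log units) apart, beyond the scatter of two such steps.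

On these data alone, it remains open whether the formyl group or the different aryl groups set the two cores apart. Also open, as far as these compounds go, is how a nitrile or a carboxylic acid in place of the formyl group would behave alongside the amino group.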